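This account rests on a few compounds, and the source may have more. Where it says the series, first, only, none or still open, it means among the compounds named here.

Measured in an ADME assay on S9 fraction from liver (Rattus norvegicus) for metabolic stability, read by LC-MS, using NADPH, with a stated time of 90 min, tested at 5 uM; a higher number here means that more of the compound is left, a lower number that less of the compound is left:
compound 1 `Cn1c(Sc2c(F)cc(C(=O)NO)cc2F)nnc1-c1cccnn1`: 58%
compound 2 `Cn1c(Sc2c(F)cc(C(=O)NO)cc2F)nnc1-c1ncccc1F`: 70%

Compound 2 stands highest of the two at 70%. Compound 3 `Cc1cc(-c2nnc(Sc3c(F)cc(C(=O)NO)cc3F)n2C)nn1C` carries 1,5-dimethyl-1H-pyrazol-3-yl in place of 3-fluoropyridin-2-yl on an aromatic carbon. For the measured compounds named here, one measured step bears on this change, made at the same place: a number 12 percentage points higher from compound 1 to compound 2 (beyond the scatter), a modest one. No five-membered ring has been measured there, so a modest step at most is expected in this assay, with a slight fall favoured. The expected step is a number 8 percentage points lower from compound 2 to compound 3 (within the scatter). For compound 3 the estimate is 62%, with an expected range of 45% to 78%.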

Compound 3, percent of the compound remaining: 30%
For compound 3 the middle estimate is 32 percentage points above the measured one, outside the stated range (below it).
By their numbers in this assay, from the lowest: compound 3; then compound 1; then compound 2.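

In this assay, the group at this position can shift the read-out far more than the change between the two six-membered rings indicated: 1,5-dimethyl-1H-pyrazol-3-yl gives a number 40 percentage points lower from compound 2 to compound 3 (beyond the scatter) and a number 28 percentage points lower from compound 1 to compound 3 (beyond the scatter). Both six-membered aromatic rings leave more compound than this five-membered aromatic ring, the only one shown here. Nothing at hand explains the fall.

As far as these compounds go, whether the fall follows the five-membered ring or its methyl groups stays open. So does whether an unsubstituted pyrazole, or a pyridine bearing an amine instead of fluorine, would match compound 2.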